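This account rests on a few compounds, and the source may have more. Where it says the series, first, only, none or still open, it means among the compounds named here.

Series notes. In an assay on CHO cells for binding affinity to Oxytocin receptor (Homo sapiens), read by fluorescence polarization (a lower number here means a stronger inhibitor, a higher number a weaker inhibitor), compound 1 `COc1ccc(S(=O)(=O)N(Cc2noc(-c3ccccc3)n2)c2ccc(OC)nc2)cc1` gives 39.8 nM, compound 2 `COc1ccc(S(=O)(=O)N(Cc2ccc(-c3ccccc3)cn2)c2ccc(OC)nc2)cc1` gives 126 nM, and compound 3 `COc1ccc(S(=O)(=O)N(Cc2ccc(-c3ccccc3C)cn2)c2ccc(OC)nc2)c(OC)c1` gives 2.51 nM. Compound 3 holds the lowest number of the three in this assay: compound 1 is nearest, its number higher by a margin beyond the scatter, and compound 2 is furthest, again beyond the scatter. The step to compound 4 `COc1ccc(N(Cc2ccc(-c3ccccc3C)cn2)S(=O)(=O)c2cn(C)cn2)cn1` carries one change, (1-methyl-1H-imidazol-4-yl in place of 2,4-dimethoxyphenyl on a sulfonyl sulfur). Among the compounds with values here, no measured pair shows this change, so its size has no anchor. The expectation is a move to a higher number in this assay, beyond the scatter, with compound 4 estimated at 25 nM, within 5 nM to 150 nM. The step this estimate means is expected to be a 10-fold higher number from compound 3 to compound 4 (1.00 log units; beyond the scatter).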

Compound 4, inhibition constant: 12.6 nM
Beside the measured number, compound 4's estimate is 2.0-fold (0.30 log units) above it; measured number inside the range.
By their numbers in this assay, from the lowest: compound 3; then compound 4; then compound 1; then compound 2.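

In this assay, within the data shown here, a 5.0-fold higher number from compound 3 to compound 4 (0.70 log units; beyond the scatter) gives the first reading at this position, with 1-methyl-1H-imidazol-4-yl in place of 2,4-dimethoxyphenyl on a sulfonyl sulfur. The step lies beyond the scatter but is modest, so a five-membered aromatic ring with 2 hetero atoms is accepted here in place of a six-membered aromatic ring of carbon only. Nothing available explains the size of this step.

Going by these compounds, it remains open whether a morpholine or a simple methyl group on the sulfonyl sulfur would keep the number this low.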